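The source may report more compounds than this note shows. Statements on the series, on what has been measured and on what is new or still open speak of the compounds shown alone.

Compound 1 `Fc1ccc(/C=C/c2cc3ccccc3nc2Cl)cc1` and compound 2 `COc1ccc2nc(Cl)c(/C=C/c3ccc(F)cc3)cc2c1` share a core, while compound 3 `FC(F)(F)c1cccc(/C=C\c2cc3ccccc3nc2Cl)c1` has a different core; the difference between the two cores is not broken down here. Compound 4 `COc1ccc2nc(Cl)c(/C=C\c3cccc(C(F)(F)F)c3)cc2c1` has not yet been measured. In a functional assay on HeLa cells (Homo sapiens) for antiproliferative activity, read by sulforhodamine B assay, with a stated time of 72 h (on this read-out lower numbers stand for stronger inhibition and higher numbers for weaker inhibition), compound 1 gives a value that is a limit of the assay, > 50000 nM. Compound 2 likewise gives a limit in this assay, > 50000 nM. The change from compound 1 to compound 2 is methoxy in place of hydrogen on an aromatic carbon, and the step that the two limits leave unreadable from compound 1 to compound 2 cannot be read, because of the limit of > 50000 nM in this assay, at which 2 of the 3 values shown sit. Among the measured compounds shown here, compound 3 is the only compound with a number in this assay, giving 2850 nM. The change from compound 3 to compound 4 is methoxy in place of hydrogen on an aromatic carbon, the same change as from compound 1 to compound 2, made on the same place. Since the measured example of this change is unreadable, the step from compound 3 to compound 4 in this assay is expected to be about a 1.1-fold higher number from compound 3 to compound 4 (0.05 log units; within the scatter), resting only on compound 3 with 2850 nM. Compound 4 is therefore estimated at 3200 nM.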

Compound 4, half-maximal inhibitory concentration: 3030 nM
Compound 4: the middle estimate sits 1.1-fold (0.02 log units) above what was measured, within the range that was stated.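

In this assay, methoxy in place of hydrogen on an aromatic carbon of the core of compound 3 gives a 1.1-fold higher number from compound 3 to compound 4 (0.03 log units; within the scatter), so on this core the two compounds cannot be told apart. The same change on the core of compound 1 cannot be read, because the values on both sides of it are limits and not numbers: the limit of > 50000 nM in this assay, at which 2 of the 4 values shown sit. The series therefore offers one readable example of this change, on one core, which shows that methoxy is tolerated there in this read-out but does not show that the change carries from one core to another.

The compounds shown hold only hydrogen or methoxy at this place, so they leave open how an amine, a carboxylic acid or a longer chain such as ethoxy would read there in this assay. They also leave open whether the outcome seen on the core of compound 3 would hold on any further core.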